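The source may report more compounds than this note shows. Statements on the series, on what has been measured and on what is new or still open speak of the compounds shown alone.

Working notes on the sulfonamide series.

Compound 3 `CCN(CC)C(=O)CN(c1ccc(C)cc1)S(=O)(=O)c1cccc(C)c1` has only a limit in a functional assay on CHO cells for inhibition of Orexin/Hypocretin receptor type 1 (Homo sapiens), read by FLIPR and calcium flux; a lower number here means a stronger inhibitor, a higher number a weaker inhibitor: compound 3 gives > 10000 nM, which is a limit of the assay and not a number. Compound 1 `CCN(CC)C(=O)CN(c1ccc(C)cc1)S(=O)(=O)c1ccc(OC)c(OC)c1` is in the same situation: in this assay compound 1 gives > 10000 nM, again a limit. Within the data shown here, the only numbered value belongs to compound 2 `CCN(C(=O)CN(c1cc(N(C)C)ccc1Cl)S(=O)(=O)c1ccc(OC)c(OC)c1)c1cccc(C)n1`, which in this assay gives 17 nM; compound 2 differs from compound 3 in several places at once, so no single step can be drawn from it. Compound 3 thus stands at the floor of what this assay reports, where two of the three values shown sit (the limit of > 10000 nM in this assay, at which 2 of the 3 values shown sit).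

Compound 4 `CCN(CC)C(=O)CN(c1ccc(C)cc1)S(=O)(=O)c1ccccc1C` keeps the same atoms as compound 3 and joins them differently: 2-methylphenyl in place of 3-methylphenyl on a sulfonyl sulfur. Among the measured compounds shown here, no measured step informs the change, and the nearest comparable compounds, compound 1 and compound 3, both sit at the limit. Compound 4 is expected to remain at or near that limit, with the step from compound 3 to compound 4 estimated as a step that the limit leaves unreadable from compound 3 to compound 4, none beyond the scatter. The expected value for compound 4 is 12000 nM, within 3000 nM to 40000 nM.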

Compound 4, half-maximal inhibitory concentration: > 10000 nM
Compound 4: a limit, no number; the forecaster's own chance of this, stated with the estimate: 75%; the middle value lies beyond the limit too.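

In this assay compound 4 gives > 10000 nM, a limit and not a number. Compound 3 also stands at a limit, so no step between compound 3 and compound 4 can be read: the limit of > 10000 nM in this assay, at which 3 of the 4 values shown sit.

The compounds shown leave open which of the several differences from compound 2, at 17 nM, matters for activity.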